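This account rests on a few compounds, and the source may have more. Where it says the series, first, only, none or still open, it means among the compounds named here.

Compound 1 `COc1ccc(-c2cn(/N=C/c3cc4ccccc4nc3Cl)c(N)n2)cc1`: > 50000 nM
Compound 2 `COc1ccc(-c2cn(/N=C/c3cc4cc(C)ccc4nc3Cl)c(N)n2)cc1`: 25700 nM
Compound 3 `Nc1nc(-c2cccc3ccccc23)cn1/N=C/c1cc2ccccc2nc1Cl`: 9480 nM

In a functional assay on DLD-1 cells (Homo sapiens) for cytotoxicity, read by MTT assay, with a stated time of 48 h (on this read-out lower numbers stand for stronger inhibition and higher numbers for weaker inhibition), compound 1 stands at the limit of > 50000 nM in this assay, at which 1 of the 3 values shown sits, so only a limit, not a number, is known for it. Compound 4 `Nc1nc(-c2cccs2)cn1/N=C/c1cc2ccccc2nc1Cl` differs from compound 1 by thiophen-2-yl in place of 4-methoxyphenyl on an aromatic carbon. For the measured compounds named here, no measured step touches this group; the only measured step, an at least 1.9-fold lower number from compound 1 to compound 2 (0.28 log units; that floor lies within the scatter), alters a different part of the shared core, and compound 3, which carries another ring at this same position, gives 9480 nM. The expectation therefore rests on little: compound 4 is estimated at 20000 nM, within 6000 nM to 60000 nM, which would mean a step of an at least 2.5-fold lower number from compound 1 to compound 4 (0.39 log units; beyond the scatter), with a real chance that the assay again reports only a limit.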

Compound 4, half-maximal inhibitory concentration: 10300 nM
Estimate against measurement, compound 4: 1.9-fold (0.29 log units) above, and the stated range covers the measured number.
By their numbers in this assay, from the lowest: compounds 3 and 4 (each within the scatter of the next); then compound 2. At a limit, above all of these: compound 1.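

At this position of the shared core, thiophen-2-yl in place of 4-methoxyphenyl gives an at least 4.8-fold lower number from compound 1 to compound 4 (0.68 log units; beyond the scatter) and so shows that a change here can move the read-out by more than the scatter. Compound 4 at 10300 nM and compound 3 at 9480 nM lie within the scatter of each other, so these two different rings read alike. Going by these compounds, the full size of the step stays unknown, as compound 1 is known only as a limit: the limit of > 50000 nM in this assay, at which 1 of the 4 values shown sits.

On these data alone, whether this position needs an aromatic ring at all stays open. An amine or an ethyl chain here would test that.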